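The compounds below may be only part of what the source reports. "The series", "measured", "known", "first", "only" and "open" are said of these compounds alone.

Measured compounds in a functional assay on MCF7 cells (Homo sapiens) for antiproliferative activity, read by MTT assay, with a stated time of 72 h; on this read-out higher numbers stand for weaker inhibition and lower numbers for stronger inhibition:
- compound 1, `O=C(Nc1ccc(Cl)c(-c2nnc3c(Cl)cccn23)c1)c1ccc(C(F)(F)F)cc1Cl`, gives 81600 nM.
- compound 2, `O=C(Nc1ccc(Cl)c(-c2nnc3c(Cl)cccn23)c1)c1cccnc1`, reaches only the limit > 100000 nM; this is a limit of the assay, not a number.
- compound 3, `CS(=O)(=O)c1ccc(C(=O)Nc2ccc(Cl)c(-c3nnc4c(Cl)cccn34)c2)c(Cl)c1`, reaches only the limit > 100000 nM; again a limit, not a number.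

Compound 2 thus stands at the assay limit, and the limit of > 100000 nM in this assay, at which 2 of the 3 values shown sit, shows it shares that position with compound 3; compound 1 alone yields a number. Within the data shown here, the one step between compounds that differ in a single place is an at least 1.2-fold higher number from compound 1 to compound 3 (0.08 log units; that floor lies within the scatter), which runs from a number into the limit and so gives only a floor.

Compound 4, `O=C(Nc1ccc(Cl)c(-c2nnc3c(Cl)cccn23)c1)c1ccon1`, differs from compound 2 by 1,2-oxazol-3-yl in place of pyridin-3-yl on a carbonyl carbon. Among the measured compounds shown here, no measured step changes the acyl ring itself, so the only guide is the neighbourhood: compound 2 at the limit, and the step from compound 1 to compound 3 showing that a change on the acyl part left compound 3 at the limit as well. The expectation for this assay is therefore no step beyond the scatter, with compound 4 most likely staying at the limit; the estimated step is a number no higher from compound 2 to compound 4 (the limit leaves the size open). Compound 4 is estimated at 100000 nM, within 40000 nM to 250000 nM.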

Compound 4, half-maximal inhibitory concentration: > 100000 nM
Compound 4 gave a limit, no number; the forecaster's own chance of this, stated with the estimate: 70%; the middle value lies on the limit itself.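

Compound 2 and compound 4 both give only a limit, not a number, in this assay, so no step can be read between them. The compounds shown leave open how pyridin-3-yl and 1,2-oxazol-3-yl on the carbonyl carbon compare in antiproliferative activity.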